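Adding a Second Chloro Group to Compound 2

The compounds below may be only part of what the source reports. "The series", "measured", "known", "first", "only" and "open" are said of these compounds alone.

Of the compounds shown here, three sharing one core have been tested in an assay (Populus sieboldii x Populus grandidentata) for inhibition of Trans-cinnamate 4-monooxygenase (Populus kitakamiensis), with a stated time of 60 min; a higher number here means a weaker inhibitor, a lower number a stronger inhibitor. Compound 1 `Sc1nnc(-c2ccccc2Cl)o1` gives 680 nM. Compound 2 `Sc1nnc(-c2cccc(Cl)c2)o1` gives 210 nM, the lowest of the two numbers, and its gap to compound 1 lies beyond the usual scatter. Compound 3 `FC(F)(F)c1cccc(-c2nnc(S)o2)c1` carries a trifluoromethyl group in place of the chloro group of compound 2. For compound 3 the assay reports only a limit, > 100000 nM, and not a number. That single measured step, an at least 470-fold higher number from compound 2 to compound 3 (2.67 log units; beyond the scatter), is anchored at the limit of > 100000 nM in this assay, at which 1 of the 3 values shown sits.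

Compound 4 `Sc1nnc(-c2cc(Cl)ccc2Cl)o1` is not yet measured. It differs from compound 2 by chloro in place of hydrogen on an aromatic carbon, so it keeps the chloro group of compound 2 and gains a second one. Within the data shown here, no measured step adds a chloro group to an existing one: the only measured step swaps chloro for trifluoromethyl, and compounds 1 and 2 merely show that a single chloro in two different positions gives two numbers set beyond the scatter. The step to compound 4 is therefore expected to stay close to that of compound 2, a 1.4-fold higher number from compound 2 to compound 4 (0.15 log units; within the scatter), with no confident direction. Compound 4 is expected to give about 300 nM in this assay, most likely between 90 nM and 1500 nM.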

Compound 4, half-maximal inhibitory concentration: 2000 nM
For compound 4 the middle estimate is 6.7-fold (0.82 log units) below the measured one, and the stated range ends below it.
By their numbers in this assay, from the lowest: compound 2; then compound 1; then compound 4. At a limit, above all of these: compound 3.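

In this assay, among these compounds, these are the first measured cases of a chloro group added to a ring that already carries one, and they move the number the same way from both single-chloro compounds: there is a 9.5-fold higher number from compound 2 to compound 4 (0.98 log units; beyond the scatter), and there is also a 2.9-fold higher number from compound 1 to compound 4 (0.47 log units; beyond the scatter). Among the compounds shown here, compounds 1 and 2 showed only that one chloro group in two different places gives two different numbers; compound 4 shows that having both an ortho and a para relationship on the ring, with the new chloro ortho to a group of 6 heavy atoms and para to a chloro group, gives a weaker inhibitor than either single-chloro compound. Within these compounds, then, more chloro does not mean a stronger inhibitor, and compound 2, with its single chloro group, remains the strongest inhibitor that has a number.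

Nothing in the data shown bears on why the second chloro group raises the number. From the compounds shown here alone, it also remains open how a different group on this same aromatic carbon, such as a fluoro group, a methoxy group or an amine, would compare with hydrogen and chloro.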